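The source may report more compounds than this note shows. Statements on the series, on what has been measured and on what is new or still open speak of the compounds shown alone.

Compound 1 `O=C(Nc1cc2cc[nH]c(=O)c2cc1Cl)C1CNCC1c1ccc(F)cc1` is the starting point. Going by the values given here, in an assay on isolated protein for inhibition of Rho-associated protein kinase 2 (Homo sapiens), read by a luciferase reporter (on this read-out lower numbers stand for stronger inhibition and higher numbers for weaker inhibition), compound 1 gives 9 nM, the highest of the three numbers measured so far. Compound 2 `Cc1cccc(C2CNCC2C(=O)Nc2cc3cc[nH]c(=O)c3cc2Cl)c1` gives 5 nM, and compound 3 `CCc1cccc(C2CNCC2C(=O)Nc2cc3cc[nH]c(=O)c3cc2Cl)c1` gives 4 nM. The change leading to compound 4 `O=C(Nc1cc2cc[nH]c(=O)c2cc1Cl)C1CNCC1c1cccc(Br)c1` is 3-bromophenyl in place of 4-fluorophenyl on a saturated ring carbon. Among the compounds with values here, two measured steps bear on it, both replacing the same 4-fluorophenyl with 3-methylphenyl or 3-ethylphenyl: a 1.8-fold lower number from compound 1 to compound 2 (0.26 log units; within the scatter) and a 2.3-fold lower number from compound 1 to compound 3 (0.35 log units; beyond the scatter). Between those two products the step of a 1.3-fold lower number from compound 2 to compound 3 (0.10 log units; within the scatter) is small. A lowering of similar, modest size is therefore expected for compound 4, around the edge of the scatter, as a 1.8-fold lower number from compound 1 to compound 4 (0.26 log units; within the scatter). Compound 4 is estimated at 5 nM, with a range from 2 nM to 12 nM.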

Compound 4, half-maximal inhibitory concentration: 2 nM
Estimate against measurement, compound 4: 2.5-fold (0.40 log units) above; low and high end bracket the measured number.
By their numbers in this assay, from the lowest: compounds 4, 3, 2 and 1 (each within the scatter of the next, the first and the last beyond it).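

In this assay the 3-bromophenyl group gives a 4.5-fold lower number from compound 1 to compound 4 (0.65 log units; beyond the scatter) at this saturated ring carbon, the largest step seen there so far. Bromo in place of methyl on the aromatic carbon gives a 2.5-fold lower number from compound 2 to compound 4 (0.40 log units; beyond the scatter) and so clears the scatter, while bromo in place of ethyl gives a 2.0-fold lower number from compound 3 to compound 4 (0.30 log units; within the scatter) and separates the two compounds no further. Nothing measured here accounts for these differences. The compounds shown leave open how a chloro, methoxy or nitrile group on the aromatic ring would compare with bromo.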